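Ring Branching One Bond Further Out: Compound 2 to Compound 4

The source may report more compounds than this note shows. Statements on the series, on what has been measured and on what is new or still open speak of the compounds shown alone.

Three amides built on one shared core have been measured in an assay on LtK cells with ATP-sensitive inward rectifier potassium channel 11 (Homo sapiens) as the target; on this read-out higher numbers stand for an effect only at larger amounts of compound and lower numbers for an effect already at smaller amounts. Compound 2 `CCCC(=O)Nc1c(C(O)(C(F)(F)F)C(F)(F)F)ccc2ccccc12`, carrying a propyl on the carbonyl carbon, gives 131 nM and stands lowest of the three numbers. Compound 1 `CC(C)C(=O)Nc1c(C(O)(C(F)(F)F)C(F)(F)F)ccc2ccccc12` gives 6630 nM, and compound 3 `CCC(C)C(=O)Nc1c(C(O)(C(F)(F)F)C(F)(F)F)ccc2ccccc12` gives 177000 nM.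

The change from compound 2 to compound 4 `O=C(CC1CCCC1)Nc1c(C(O)(C(F)(F)F)C(F)(F)F)ccc2ccccc12` is cyclopentyl in place of ethyl on a saturated chain carbon bound to a carbonyl carbon. Read one bond further out, this is propyl becoming cyclopentylmethyl, so the added carbon sits one bond further from the carbonyl than in compound 1 or compound 3.

All three measured steps concern added carbon close to the carbonyl. a 51-fold lower number from compound 1 to compound 2 (1.70 log units; beyond the scatter). a 1400-fold higher number from compound 2 to compound 3 (3.13 log units; beyond the scatter). a 27-fold higher number from compound 1 to compound 3 (1.43 log units; beyond the scatter). Each methyl added on the saturated chain carbon bound to the carbonyl carbon raised the number strongly. Compound 4 adds more carbon still, though further along the chain, and a rise is therefore expected for compound 4 because a 1400-fold higher number from compound 2 to compound 3 (3.13 log units; beyond the scatter) and a 51-fold lower number from compound 1 to compound 2 (1.70 log units; beyond the scatter) both point the same way, yet a smaller one than those. For compound 4 the expected step is a 4.6-fold higher number from compound 2 to compound 4 (0.66 log units; beyond the scatter), leading to an estimate of 600 nM with a range from 100 nM to 4000 nM.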

Compound 4, half-maximal effective concentration: 81 nM
Beside the measured number, compound 4's estimate is 7.4-fold (0.87 log units) above it; measured number outside the range, below it.
By their numbers in this assay, from the lowest: compounds 4 and 2 (each within the scatter of the next); then compound 1; then compound 3.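

In this assay, cyclopentyl in place of ethyl on a saturated chain carbon bound to a carbonyl carbon gives a 1.6-fold lower number from compound 2 to compound 4 (0.21 log units; within the scatter) at this position, so the larger group with its five-membered ring leaves the number where it was. The picture differs sharply for the two compounds branched directly on the carbon bound to the carbonyl: the change to cyclopentylmethyl gives a 2200-fold lower number from compound 3 to compound 4 (3.34 log units; beyond the scatter) and also an 82-fold lower number from compound 1 to compound 4 (1.91 log units; beyond the scatter) in this same series. Across these four compounds, then, the count of added carbon does not by itself set the number, and the large rises go with branching on the carbon bound to the carbonyl, while branching one bond further out, in compound 4, goes with no rise at all.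

No measurement shown here explains why the place of the branch matters so much.
Going by these compounds, it also remains open whether a cyclohexyl ring, a longer straight chain such as pentyl, or an amine on the cyclopentyl ring would keep the number this low in the same assay.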